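The source may hold more compounds than are shown below. What is called first, only, known or untested is meant among the compounds shown, and "the series" means these compounds.

Measured in a toxicity assay on NIH3T3 cells (Mus musculus) for cytotoxicity, read by resazurin assay; a lower number here means that less compound is needed, a higher number that more compound is needed for the effect:
- compound 1 `c1ccc(-c2ccc(Cn3cncc3CNc3ccc(-c4nc5ccccc5s4)c(-c4ccccc4)c3)cc2)cc1`: > 1000 nM (a limit)
- compound 2 `COC(=O)c1ccc(NCc2cncn2Cc2ccc(-c3ccccc3)cc2)cc1-c1ccccc1`: > 1000 nM (a limit)

Compound 1 stands only at a limit, > 1000 nM. Compound 3 `Cc1ccccc1-c1cc(NCc2cncn2Cc2ccc(-c3ccccc3)cc2)ccc1-c1nc2ccccc2s1` carries methyl in place of hydrogen on an aromatic carbon, methyl in place of hydrogen on an aromatic carbon. Among the measured compounds shown here, the one measured step, a step that the two limits leave unreadable from compound 1 to compound 2, replaces a different group and has no readable size. What the series shows so far is the limit of > 1000 nM in this assay, at which 2 of the 2 values shown sit. In this assay no shift beyond the scatter is therefore expected, in either direction, and the expected step is a step that the limit leaves unreadable from compound 1 to compound 3. For compound 3 the estimated value is 2000 nM, with an expected range of 700 nM to 6000 nM.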

Compound 3, half-maximal effective concentration: > 1000 nM
Compound 3 was reported as a limit (the forecaster's own chance of this, stated with the estimate: 80%); the middle value lies beyond the limit too.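

Among the compounds shown here, compound 3 stands only at a limit, > 1000 nM, as compound 1 does, so no step between them can be read in this assay. The compounds shown leave open whether 2-methylphenyl in place of phenyl changes cytotoxicity at all.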